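The source may report more compounds than this note shows. Statements on the series, on what has been measured and on what is new or still open speak of the compounds shown alone.

Working notes on the series.

Three members of the series have been measured in a functional assay on CHO cells for agonist activity at Free fatty acid receptor 1 (Homo sapiens), read by FLIPR and calcium flux, in the presence of a further agent that is not named here; a higher number here means that more compound is needed for the effect, a lower number that less compound is needed. Compound 1 `CCc1ccc(-c2noc(COc3ccc(CCC(=O)O)cc3)n2)cc1` gives 210 nM. Compound 2 `Cc1ccc(-c2noc(COc3ccc(CCC(=O)O)cc3)n2)cc1` gives 300 nM. Compound 3 `O=C(O)CCc1ccc(OCc2nc(-c3ccc(Cl)cc3)no2)cc1` gives 540 nM. All three share the same core and differ only in the group on the outer aromatic ring. Compound 2 and compound 3 differ by chloro in place of methyl on an aromatic carbon, and the numbers move a 1.8-fold higher number from compound 2 to compound 3 (0.26 log units; within the scatter). Compound 1 and compound 3 are set apart by a 2.6-fold higher number from compound 1 to compound 3 (0.41 log units; beyond the scatter), so compound 3 stands at the high end of the three, though its gap to compound 2 does not exceed the scatter.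

Compound 4 `CC(Oc1ccc(CCC(=O)O)cc1)c1nc(-c2ccc(Cl)cc2)no1` has not yet been measured in this assay. It differs from compound 3 by methyl in place of hydrogen on a saturated chain carbon bound to an aromatic carbon and an oxygen on an aromatic ring. A change of the same kind is already on record within the series: compound 2 and compound 1 differ by methyl in place of hydrogen on a saturated chain carbon bound to an aromatic carbon, and that step reads a 1.4-fold lower number from compound 2 to compound 1 (0.15 log units; within the scatter). The two changes are not the same, however: in the measured pair the carbon that takes the methyl is bound to an aromatic carbon only, whereas in compound 4 it is bound to an aromatic carbon and an oxygen on an aromatic ring. The difference between the core of compound 3 and that of compound 2 is chloro in place of methyl on an aromatic carbon, and this distinction carries over to compound 4.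

Among the measured compounds shown here, on the basis of the one measured precedent, compound 1 against compound 2 with a 1.4-fold lower number from compound 2 to compound 1 (0.15 log units; within the scatter), the methyl in compound 4 is expected to shift the number little, so the estimated step is a 1.3-fold lower number from compound 3 to compound 4 (0.11 log units; within the scatter). Compound 4 is therefore expected to give about 420 nM in this assay, with a range from 150 nM to 1200 nM to cover the scatter and the different surroundings of the added methyl.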

Compound 4, half-maximal effective concentration: 500 nM
The estimate for compound 4 lay 1.2-fold (0.08 log units) below the measured number; the measured number falls inside the stated range.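

In this assay, methyl in place of hydrogen on a saturated chain carbon bound to an aromatic carbon and an oxygen on an aromatic ring reads a 1.1-fold lower number from compound 3 to compound 4 (0.03 log units; within the scatter) on the chloro core. Set beside the earlier methyl step on the methyl core, the reading carries over, with both steps within the scatter and no measurable difference between the two cores: the same change on two cores in this assay, a 1.4-fold lower number (0.15 log units; within the scatter) from compound 2 to compound 1 and a 1.1-fold lower number (0.03 log units; within the scatter) from compound 3 to compound 4, 1.3-fold (0.12 log units) apart, within the scatter of two such steps. This does not show that the methyl is without consequence on every core of the series, since it rests on two pairs only, and the carbon taking the methyl is not bound in the same way in the two pairs, so core and surroundings are not separated.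

Open, as far as these compounds go, is how a larger group such as ethyl or isopropyl, or a hydroxyl, would read in place of the methyl on that chain carbon. Also open, from the compounds shown here alone, is whether the agreement holds when a methoxy or a trifluoromethyl stands in place of the chloro, or when a longer chain stands in place of the propanoic acid chain.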